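From 2-methoxyphenyl to 3-chlorophenyl on the amide-type nitrogen

A few compounds are considered here, and "the series" means these few. Any claim that something is new, unique, unknown or untested is made for them only; others in the source may bear on it.

Within the data shown here, in an ADME assay on HUVEC cells (Homo sapiens) for cytotoxicity, read by MTT assay, with a stated time of 72 h (a lower number here means a stronger inhibitor, a higher number a weaker inhibitor), compound 1 `O=C(CCC(=O)OCCCCCCSc1ccc([N+](=O)[O-])c2nonc12)Nc1ccccc1F` gives 840 nM and compound 2 `COc1ccccc1NC(=O)CCC(=O)OCCCCCCSc1ccc([N+](=O)[O-])c2nonc12` gives 1610 nM and these two numbers lie within the scatter of each other, so compound 2 stands level with the only other measured compound. Compound 3 `O=C(CCC(=O)OCCCCCCSc1ccc([N+](=O)[O-])c2nonc12)Nc1cccc(Cl)c1` carries 3-chlorophenyl in place of 2-methoxyphenyl on an amide-type nitrogen and is otherwise unchanged. Among the measured compounds shown here, the one measured step that bears on this, methoxy in place of fluoro on an aromatic carbon, gives a 1.9-fold higher number from compound 1 to compound 2 (0.28 log units; within the scatter) and stays within the scatter. For the measured compounds named here, no measured compound holds the 3-chlorophenyl group, so that step is only a rough guide. A step beyond the scatter in this assay is therefore not expected, in either direction. The expected change is a 1.4-fold lower number from compound 2 to compound 3 (0.15 log units; within the scatter) and would stay inside the scatter. Compound 3 is estimated at 1150 nM with an expected range from 400 nM to 3300 nM for repeated measurements.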

Compound 3, half-maximal inhibitory concentration: 1090 nM
The estimate for compound 3 lay 1.1-fold (0.02 log units) above the measured number, and the stated range covers the measured number.
By their numbers in this assay, from the lowest: compounds 1, 3 and 2 (each within the scatter of the next).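

In this assay, replacing the group on the amide-type nitrogen gives a 1.5-fold lower number from compound 2 to compound 3 (0.17 log units; within the scatter), and a second replacement at the same place gives a 1.3-fold higher number from compound 1 to compound 3 (0.11 log units; within the scatter). The earlier comparison covered only methoxy and fluoro, whereas these steps add 3-chlorophenyl and show that 2-fluorophenyl, 2-methoxyphenyl and 3-chlorophenyl cannot be told apart at this position in this assay. No supporting measurement speaks to why these three numbers sit together.

Going by these compounds, all three compounds keep a substituted phenyl ring on this nitrogen, so it remains open whether a plain phenyl, a pyridine ring or a small alkyl group such as methyl would stay level with them. On these data alone, whether a shorter or longer chain between the ester and the shared core would change the number also remains open.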